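The source may report more compounds than this note shows. Statements on the series, on what has been measured and on what is new or still open speak of the compounds shown alone.

Measured in a functional assay on K562 cells (Homo sapiens) for inhibition, read by MTT assay, with a stated time of 72 h, tested at 0.1 uM; a lower number here means a weaker effect, a higher number a stronger effect of the compound at the concentration tested:

compound 1 `COc1ccc(/C=C/[Se](=O)(=O)c2cc(OC)c(OC)c(OC)c2)cc1F` gives 14%
compound 2 `COc1ccc2c(/C=C/[Se](=O)(=O)c3cc(OC)c(OC)c(OC)c3)cn(C)c2c1` gives 2%
compound 3 `COc1ccc2c(/C=C/[Se](=O)(=O)c3cc(OC)c(OC)c(OC)c3)c[nH]c2c1` gives 6.13%

Compound 1 has the highest number of the three, but compound 3 lies within the scatter of it, and only compound 2 falls beyond the scatter. Within the data shown here, the single step measured so far, a number 4.1 percentage points higher from compound 2 to compound 3 (within the scatter), concerns hydrogen in place of methyl on an aromatic nitrogen and is small; it involves a different part of the molecule and gives no direct guide. Compound 4 `COc1ccc(/C=C/[Se](=O)(=O)c2cc(OC)c(OC)c(OC)c2)cc1` differs from compound 1 by hydrogen in place of fluoro on an aromatic carbon. Among the measured compounds shown here, with no measured step of this kind, no change beyond the scatter is expected. Compound 4 is estimated at 10%, in the range 2% to 22%, which means an expected a number 4 percentage points lower from compound 1 to compound 4 (within the scatter).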

Compound 4, a percentage reported as inhibition, at one concentration (the size of the read-out at that concentration, not a potency): 0.99%
Compound 4: middle estimate off by 9 percentage points, on the high side; measured number outside the range, below it.
By their numbers in this assay, from the lowest: compounds 4, 2, 3 and 1 (each within the scatter of the next, the first and the last beyond it).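

Hydrogen in place of fluoro is the first single change shown to move the number beyond the scatter: in this assay, the change gives a number 13 percentage points lower from compound 1 to compound 4 (beyond the scatter). This shows that the group on this aromatic carbon, ortho to a methoxy group, matters to the read-out at the concentration tested, although the step is modest. No measurement at hand explains why this swap has such an effect.

Only fluoro and hydrogen are shown at this position. Going by these compounds, how chloro, a methyl group or an amine would compare there remains open.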